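A few compounds are considered here, and "the series" means these few. Any claim that something is new, unique, unknown or untested is made for them only; others in the source may bear on it.

Among the measured compounds shown here, in a functional assay on COLO 205 cells (Homo sapiens) for inhibition, read by sulforhodamine B assay (on this read-out higher numbers stand for weaker inhibition of growth and lower numbers for stronger inhibition of growth), compound 1 `c1ccc(-c2ccc(-c3ccc(-c4nc5ccccc5[nH]4)cc3)cc2)cc1` gives 100000 nM, compound 2 `COc1ccc(-c2ccc(-c3ccc(-c4nc5ccccc5[nH]4)cc3)cc2)cc1OC` gives 41200 nM, and compound 3 `Oc1cccc2[nH]c(-c3ccc(-c4ccc(-c5ccccc5)cc4)cc3)nc12` gives 1210 nM, the lowest of the three numbers so far. For the measured compounds named here, two measured steps bear on what comes next. Putting hydroxy in place of hydrogen on an aromatic carbon produced an 83-fold lower number from compound 1 to compound 3 (1.92 log units; beyond the scatter), a large move. Putting 3,4-dimethoxyphenyl in place of phenyl produced a 2.4-fold lower number from compound 1 to compound 2 (0.39 log units; beyond the scatter), a modest move.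

Compound 4 `Oc1cccc2[nH]c(-c3ccc(-c4ccc(-c5ccc(OC(F)(F)F)cc5)cc4)cc3)nc12` keeps the hydroxy of compound 3 and carries one further change, trifluoromethoxy in place of hydrogen on an aromatic carbon, para to a large group: trifluoromethoxy in place of hydrogen on an aromatic carbon. Read one bond further out, this is phenyl to 4-(trifluoromethoxy)phenyl, so the phenyl that changed in compound 2 changes again. The hydroxy step was made elsewhere on the molecule and says little here. The dimethoxy step, a 2.4-fold lower number from compound 1 to compound 2 (0.39 log units; beyond the scatter), is the nearer guide, but it is a loose one, since it involves different groups and a compound without the hydroxy. Going by the values given here, no measured compound carries trifluoromethoxy. A modest move toward a lower number is therefore expected, not a large one, and an estimated 1.6-fold lower number from compound 3 to compound 4 (0.21 log units; within the scatter) reflects this. Compound 4 is expected at 750 nM, with an estimated range of 230 nM to 2500 nM.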

Compound 4, concentration for 50% growth inhibition: 8320 nM
For compound 4 the middle estimate is 11-fold (1.05 log units) below the measured one, and the stated range ends below it.
By their numbers in this assay, from the lowest: compound 3; then compound 4; then compound 2; then compound 1.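

In this assay, changing phenyl to 4-(trifluoromethoxy)phenyl on the hydroxy-bearing compound gives a 6.9-fold higher number from compound 3 to compound 4 (0.84 log units; beyond the scatter), so a group added para to a large group on this outer ring can raise the number and weaken growth inhibition. Among the compounds shown here, the only earlier change at this ring, a 2.4-fold lower number from compound 1 to compound 2 (0.39 log units; beyond the scatter), went the opposite way, which shows that the direction of change here depends on what is placed on the ring, although that earlier pair lacks the hydroxy and carries different groups, so the two steps are only a loose comparison. Nothing available here explains why the number rose with trifluoromethoxy.

The compounds shown leave open whether another group at this same place, such as a single methoxy, a fluorine, an amine or a carboxylic acid, would raise the number as trifluoromethoxy does or lower it. They also leave open whether 3,4-dimethoxyphenyl would still lower the number when the hydroxy of compound 3 is present, and so whether the effects of the two places on the molecule simply add together.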